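A Smaller Side Chain on Compound 2

This account rests on a few compounds, and the source may have more. Where it says the series, first, only, none or still open, it means among the compounds named here.

In a functional assay on DU-145 cells (Homo sapiens) for cytotoxicity, read by MTT assay (a lower number here means a stronger inhibitor, a higher number a weaker inhibitor), compound 1 `CCCCCCC(C)(O)CC(=O)O[C@H](CC=C(C)C)C1=CC(=O)c2c(O)ccc(O)c2C1=O` gives > 100000 nM, which is a limit and not a number. For the measured compounds named here, compound 2 `CC(C)=CC[C@@H](OC(=O)CC(C)(O)C(C)C)C1=CC(=O)c2c(O)ccc(O)c2C1=O` gives 16900 nM, the only true number so far. Compound 3 `CC[C@@](C)(O)CC(=O)O[C@H](CC=C(C)C)C1=CC(=O)c2c(O)ccc(O)c2C1=O` differs from compound 2 in one group on a saturated chain carbon bound to a carbonyl carbon: 1-hydroxy-1-methylpropyl in place of 1-hydroxy-1,2-dimethylpropyl on a saturated chain carbon bound to a carbonyl carbon. Going by the values given here, the one measured step, an at least 5.9-fold lower number from compound 1 to compound 2 (0.77 log units; beyond the scatter), put isopropyl in place of hexyl, and it starts from a limit. It gives only a weak guide, so little change is expected: the estimated step is a 1.1-fold lower number from compound 2 to compound 3 (0.05 log units; within the scatter), not beyond the scatter. For compound 3 the estimated value is 15000 nM, with an expected range of 6000 nM to 40000 nM.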

Compound 3, half-maximal inhibitory concentration: 12700 nM
Estimate against measurement, compound 3: 1.2-fold (0.07 log units) above; low and high end bracket the measured number.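

In this assay, 1-hydroxy-1-methylpropyl in place of 1-hydroxy-1,2-dimethylpropyl gives a 1.3-fold lower number from compound 2 to compound 3 (0.12 log units; within the scatter), so these two side chains cannot be told apart. Set against the longer 1-hydroxy-1-methylheptyl, the same 1-hydroxy-1-methylpropyl gives an at least 7.8-fold lower number from compound 1 to compound 3 (0.89 log units; beyond the scatter), so both shorter chains now separate from compound 1. The value of compound 1 is a limit and not a number, so the true size of that step stays unknown: the limit of > 100000 nM in this assay, at which 1 of the 3 values shown sits.

The compounds shown leave open where between these chains the drop sets in, as a butyl or pentyl chain could show. They also leave open how an amine or a carboxylic acid on this chain would read.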